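Aryl esters of a shared core: nitro for methyl

A few compounds are considered here, and "the series" means these few. Any claim that something is new, unique, unknown or untested is made for them only; others in the source may bear on it.

Measured so far:
compound 1 `COc1cccc(C(=O)Oc2cc3c(cc2C)[C@@H](C(C)C)CC=C3C)c1` — 16.3%
compound 2 `CC1=CC[C@H](C(C)C)c2cc(C)c(OC(=O)c3ccc(Cl)cc3)cc21` — 34.1%
compound 3 `CC1=CC[C@H](C(C)C)c2cc(C)c(OC(=O)c3cccc(C)c3)cc21` — 38.6%

In a functional assay on PC-3 cells (Homo sapiens) for antiproliferative activity, read by sulforhodamine B assay, with a stated time of 48 h, tested at 50 uM (on this read-out higher numbers stand for more inhibition at the one concentration tested (going by the name of the read-out) and lower numbers for less inhibition), compound 3 has the highest of the three numbers; compound 2 sits within the scatter of it, compound 1 lies beyond the scatter below. Compound 4 `CC1=CC[C@H](C(C)C)c2cc(C)c(OC(=O)c3cccc([N+](=O)[O-])c3)cc21` differs from compound 3 by nitro in place of methyl on an aromatic carbon. Going by the values given here, no measured step exchanges methyl for nitro. Among the compounds with values here, the nearest precedent changes the group at the same place, a number 22.3 percentage points higher from compound 1 to compound 3 (beyond the scatter), and the aryl exchange a number 17.8 percentage points higher from compound 1 to compound 2 (beyond the scatter) shows that this part of the molecule moves the read-out by modest amounts. Both point to a modest shift in this assay without fixing its direction, so compound 4 is expected to fall slightly below compound 3, at 30% (range 10% to 55%), an estimated step of a number 8.6 percentage points lower from compound 3 to compound 4 (within the scatter).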

Compound 4, a percentage reported as inhibition, at one concentration (the size of the read-out at that concentration, not a potency): 36.9%
Beside the measured number, compound 4's estimate is 6.9 percentage points below it; the range from low to high includes it.
By their numbers in this assay, from the lowest: compound 1; then compounds 2, 4 and 3 (each within the scatter of the next).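

In this assay, nitro in place of methyl on the aromatic carbon gives a number 1.7 percentage points lower from compound 3 to compound 4 (within the scatter), so these two groups cannot be told apart at this place. The 3-nitrophenyl ester likewise cannot be separated from the 4-chlorophenyl ester, with a number 2.8 percentage points higher from compound 2 to compound 4 (within the scatter), while the 3-methoxyphenyl ester remains the only one set apart, with a number 20.6 percentage points higher from compound 1 to compound 4 (beyond the scatter). Nothing available bears on the reason for this result. Going by these compounds, whether an amine or a carboxylic acid at this place would stay level with compound 3 remains open. So does whether a longer chain in place of methoxy would lift the number as methyl and nitro do.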